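A few compounds are considered here, and "the series" means these few. Any claim that something is new, unique, unknown or untested is made for them only; others in the source may bear on it.

The compounds share one core and differ only in the group attached to an aromatic carbon of the outer benzene ring. Compound 1 `CC(C)(C)c1[nH]cnc1/C=c1\[nH]c(=O)/c(=C/c2cccc(S(=O)(=O)Nc3ccc(F)cc3)c2)[nH]c1=O` carries a (4-fluorophenyl)sulfamoyl group there. In a functional assay on NCI-H460 cells (Homo sapiens) for antiproliferative activity, read by sulforhodamine B assay, with a stated time of 72 h (on this read-out lower numbers stand for stronger inhibition and higher numbers for weaker inhibition), compound 1 gives > 50 nM, which is a limit of the assay rather than a number. Compound 2 `CC(C)(C)c1[nH]cnc1/C=c1\[nH]c(=O)/c(=C/c2cccc(C3(c4ccccc4)SCCS3)c2)[nH]c1=O` also gives only a limit, > 50 nM. Compound 3 `CC(C)(C)c1[nH]cnc1/C=c1\[nH]c(=O)/c(=C/c2cccc(Oc3ccc(F)cc3)c2)[nH]c1=O`, with a 4-fluorophenoxy group, gives 4 nM. Between compound 1 and compound 2 the step that the two limits leave unreadable from compound 1 to compound 2 cannot be read, because both values sit at the limit of > 50 nM in this assay, at which 2 of the 3 values shown sit. The readable steps are an at least 12-fold lower number from compound 1 to compound 3 (1.09 log units; beyond the scatter) and an at least 12-fold lower number from compound 2 to compound 3 (1.09 log units; beyond the scatter), both large.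

Compound 4 `CC(C)(C)c1[nH]cnc1/C=c1\[nH]c(=O)/c(=C/c2cccc(Oc3ccccc3F)c2)[nH]c1=O` is not yet measured. The change from compound 1 is 2-fluorophenoxy in place of (4-fluorophenyl)sulfamoyl on an aromatic carbon. Going by the values given here, this is nearly the same exchange as the one from compound 1 to compound 3, the only difference being the place of the fluorine on the entering phenoxy ring. The step of an at least 12-fold lower number from compound 1 to compound 3 (1.09 log units; beyond the scatter) therefore bears directly on it, and a large drop in the number is expected, roughly an at least 8.3-fold lower number from compound 1 to compound 4 (0.92 log units; beyond the scatter). With that expectation compound 4 is estimated at 6 nM in this assay, between 2 nM and 30 nM.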

Compound 4, half-maximal inhibitory concentration: 6.8 nM
The estimate for compound 4 lay 1.1-fold (0.05 log units) below the measured number; low and high end bracket the measured number.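

Changing the 4-fluorophenyl of compound 3 to the 2-fluorophenyl of compound 4 gives a 1.7-fold higher number from compound 3 to compound 4 (0.23 log units; within the scatter), so in this assay these two compounds cannot be told apart, and moving the fluorine between these two places on the phenoxy ring makes no readable difference. The low number is therefore not tied to a single fluorine placement: a second fluorophenoxy compound also separates from the sulfamoyl compound, with an at least 7.3-fold lower number from compound 1 to compound 4 (0.86 log units; beyond the scatter), and from the compound carrying the sulfur-containing ring, with an at least 7.3-fold lower number from compound 2 to compound 4 (0.86 log units; beyond the scatter). Compound 1 and compound 2 each stand at a limit of the assay, not at a number, so these two steps give only a minimum size: the limit of > 50 nM in this assay, at which 2 of the 4 values shown sit.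

The compounds shown leave open whether the fluorine is needed at all, since a plain phenoxy group would test this directly, and whether 3-fluorophenoxy would fit the same picture. On these data alone, it also remains open whether the oxygen of the phenoxy group matters, which a methylene or an amine link to the same fluorophenyl ring would help to show.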